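The compounds below may be only part of what the source reports. "The series", "measured", "known", "first", "only" and "open" are said of these compounds alone.

Series notes, variation of the amide aryl group on a shared core.

Compound 1 `COc1cc(C(=O)Nc2ccc(C(=O)/C=C/c3nc(C)c(C)nc3C)cc2)cc(OC)c1OC` — 2760 nM in a functional assay on MCF7 cells (Homo sapiens) for antiproliferative activity, read by CCK-8 assay, with a stated time of 72 h; a lower number here means a stronger inhibitor, a higher number a weaker inhibitor
Compound 2 `COc1cccc(OC)c1C(=O)Nc1ccc(C(=O)/C=C/c2nc(C)c(C)nc2C)cc1` — 2470 nM
Compound 3 `Cc1nc(C)c(/C=C/C(=O)c2ccc(NC(=O)c3ccc(F)cc3)cc2)nc1C` — 1540 nM

Compound 2 stands second highest of the three numbers; compound 1 lies within the scatter of it, and compound 3 also lies within the scatter of it. Compound 4 `COc1cc(OC)cc(C(=O)Nc2ccc(C(=O)/C=C/c3nc(C)c(C)nc3C)cc2)c1` differs from compound 2 by 3,5-dimethoxyphenyl in place of 2,6-dimethoxyphenyl on a carbonyl carbon. Among the compounds with values here, the only single-point step at this position, a 1.6-fold lower number from compound 2 to compound 3 (0.21 log units; within the scatter), did not exceed the scatter, and the three aryl variants together span no more than that; no step beyond the scatter is therefore expected in this assay, in either direction. Compound 4 is expected at 2500 nM, between 1200 nM and 5000 nM, the step of a 1.0-fold higher number from compound 2 to compound 4 (0.01 log units; within the scatter) being expected to remain within the scatter.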

Compound 4, half-maximal inhibitory concentration: 6270 nM
Compound 4: middle estimate off by 2.5-fold (0.40 log units), on the low side, outside the stated range (above it).
By their numbers in this assay, from the lowest: compounds 3, 2 and 1 (each within the scatter of the next); then compound 4.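

In this assay, within the data shown here, this position responds to how the methoxy groups are arranged and not only to which atoms are present: 3,5-dimethoxyphenyl in place of 2,6-dimethoxyphenyl, with the same atoms joined differently, gives a 2.5-fold higher number from compound 2 to compound 4 (0.40 log units; beyond the scatter) and is the first step here beyond the scatter. The same aryl group also stands apart from 4-fluorophenyl, with a 4.1-fold higher number from compound 3 to compound 4 (0.61 log units; beyond the scatter) and hydrogen in place of methoxy on an aromatic carbon reads as a 2.3-fold higher number from compound 1 to compound 4 (0.36 log units; beyond the scatter) in the reverse sense. Nothing at hand accounts for these steps.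

Open, going by these compounds, is how a hydroxy or amine group in place of methoxy on an aromatic carbon would read at this position.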